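The compounds below may be only part of what the source reports. "The series", "measured", "known", "first", "only" and "open" are said of these compounds alone.

Working notes on the series. Compound 1 `CNC(=O)c1ccncc1Nc1cc(-c2ccc3ccn(C)c3c2)c2nccnc2c1` carries hydrogen on the saturated chain carbon bound to the amide-type nitrogen; in an assay for inhibition of 6-phosphofructo-2-kinase/fructose-2,6-bisphosphatase 3 (Homo sapiens), read by ADP-Glo, with a stated time of 2 h (on this read-out lower numbers stand for stronger inhibition and higher numbers for weaker inhibition), compound 1 gives 83 nM. Among the compounds with values here, compound 2 `Cn1cc(CNC(=O)c2ccncc2Nc2cc(-c3ccc4ccn(C)c4c3)c3nccnc3c2)cn1` gives 159 nM in this assay, the highest of the two numbers so far; its nearest neighbour is compound 1, and the step of a 1.9-fold higher number from compound 1 to compound 2 (0.28 log units; within the scatter) lies within the scatter. Compound 3 `CN1CCC(NC(=O)c2ccncc2Nc2cc(-c3ccc4ccn(C)c4c3)c3nccnc3c2)CC1` is not yet measured. It differs from compound 2 by 1-methylpiperidin-4-yl in place of (1-methyl-1H-pyrazol-4-yl)methyl on an amide-type nitrogen. Within the data shown here, only the single measured step at this position bears on the change, and it stayed within the scatter, so no step beyond the scatter is expected in this assay for the exchange of one seven-heavy-atom group for another. The expected step from compound 2 to compound 3 is a 1.1-fold lower number from compound 2 to compound 3 (0.03 log units; within the scatter), essentially none. Compound 3 is therefore estimated at 150 nM in this assay, with a range of 50 nM to 450 nM.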

Compound 3, half-maximal inhibitory concentration: 38 nM
Compound 3: middle estimate off by 3.9-fold (0.60 log units), on the high side; measured number below the stated range.
By their numbers in this assay, from the lowest: compound 3; then compounds 1 and 2 (each within the scatter of the next).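

In this assay the substituent on the amide-type nitrogen does move the number: the exchange of (1-methyl-1H-pyrazol-4-yl)methyl for 1-methylpiperidin-4-yl gives (a 4.2-fold lower number from compound 2 to compound 3 (0.62 log units; beyond the scatter)), although both groups count 7 heavy atoms and carry no net charge. The same group in place of methyl gives (a 2.2-fold lower number from compound 1 to compound 3 (0.34 log units; beyond the scatter)), so 1-methylpiperidin-4-yl separates from methyl, while the step to (1-methyl-1H-pyrazol-4-yl)methyl stayed within the scatter. No supporting data bear on this difference between the two groups. The compounds shown leave open whether the change follows the six-membered non-aromatic ring itself, its nitrogen or the methyl on that nitrogen. Cyclohexyl, piperidin-4-yl and (1-methylpiperidin-4-yl)methyl on the same amide-type nitrogen would separate these readings.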